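Bromo to phenyl on a thiophene: expected cytotoxicity shift

The source may hold more compounds than are shown below. What is called first, only, known or untested is meant among the compounds shown, and "the series" means these compounds.

Measured compounds:
Compound 1, `C[C@H]1[C@H](NCc2cc(C3CC3)cs2)C[C@H]2C[C@@H]1C2(C)C`, gives 25000 nM in an ADME assay on MDCK cells (Canis lupus familiaris) for cytotoxicity, read by microscopy, with a stated time of 48 h; on this read-out lower numbers stand for higher toxicity in this test and higher numbers for lower toxicity in this test.
Compound 2, `CCc1csc(CN[C@@H]2C[C@H]3C[C@@H]([C@H]2C)C3(C)C)c1`, gives 25000 nM in this assay.
Compound 3, `C[C@H]1[C@H](NCc2cc(Br)cs2)C[C@H]2C[C@@H]1C2(C)C`, gives 6250 nM in this assay.

Compound 3 holds the lowest number of the three, so it is the most cytotoxic in this assay here; its nearest neighbour on the numbers is compound 1, and compound 2 sits at the same number as compound 1. The unmeasured compound 4 is `C[C@H]1[C@H](NCc2cc(-c3ccccc3)cs2)C[C@H]2C[C@@H]1C2(C)C`. It differs from compound 3 in one place: phenyl in place of bromo on an aromatic carbon.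

Among the compounds with values here, two measured steps bear on this change. Both exchange the bromo of compound 3 against a carbon group on the same ring carbon: a 4.0-fold lower number from compound 1 to compound 3 (0.60 log units; beyond the scatter) and a 4.0-fold lower number from compound 2 to compound 3 (0.60 log units; beyond the scatter). Read in the direction of interest, each carbon group on that ring carbon gave a higher number than the bromo. Phenyl is also a carbon group, so a step upward from compound 3 is expected in this assay, though phenyl is larger than either of the groups measured, which leaves room for a smaller or larger move. The expected step is a 2.0-fold higher number from compound 3 to compound 4 (0.30 log units; within the scatter). Compound 4 is therefore estimated at 12500 nM, with a range from 5000 nM to 30000 nM.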

Compound 4, minimum cytotoxic concentration: 5000 nM
Estimate against measurement, compound 4: 2.5-fold (0.40 log units) above; the range from low to high includes it.
By their numbers in this assay, from the lowest: compounds 4 and 3 (each within the scatter of the next); then compounds 1 and 2 (each within the scatter of the next).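

In this assay the swap of bromo for phenyl, on the ring carbon two ring bonds from the ring sulfur, gives a 1.3-fold lower number from compound 3 to compound 4 (0.10 log units; within the scatter) and so places these two very different groups together on this read-out. Phenyl does not group with the other two carbon groups at this position, as shown by a 5.0-fold lower number from compound 2 to compound 4 (0.70 log units; beyond the scatter) and by a 5.0-fold lower number from compound 1 to compound 4 (0.70 log units; beyond the scatter), so carrying a carbon group here does not by itself go with the higher numbers of compound 1 and compound 2. Nothing in the available data gives a reason for this grouping.

The compounds shown leave open whether other groups on this ring carbon, such as an amine, a carboxylic acid, a methoxy group or a longer chain like butyl, would fall with compound 3 and compound 4 or with compound 1 and compound 2. They also leave open whether a pyridine ring, or a phenyl carrying a fluorine, would stay with compound 4 on this read-out.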